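The compounds below may be only part of what the source reports. "The series", "measured", "known", "first", "only" and "open" are said of these compounds alone.

In a functional assay on EBC-1 cells (Homo sapiens) for antiproliferative activity, with a stated time of 72 h (on this read-out higher numbers stand for weaker inhibition and lower numbers for stronger inhibition), compound 1 (`CN(C)CCNC(=O)c1ccc(-c2cc(F)c3ncc(Cc4ccc5ncccc5c4)n3c2)cc1F`) gives 49 nM, while compound 2 (`O=C(NCCCN1CCCC1)c1ccc(-c2cc(F)c3ncc(Cc4ccc5ncccc5c4)n3c2)cc1F`) gives 161 nM, the higher of the two numbers. Compound 3 (`O=C(NCc1ccccn1)c1ccc(-c2cc(F)c3ncc(Cc4ccc5ncccc5c4)n3c2)cc1F`) differs from compound 2 as follows: pyridin-2-yl in place of 2-(pyrrolidin-1-yl)ethyl on a saturated chain carbon bound to an amide-type nitrogen. Going by the values given here, the only measured guide is a 3.3-fold higher number from compound 1 to compound 2 (0.52 log units; beyond the scatter), a modest step that did not involve a pyridin-2-yl group, so it offers no firm direction and no step beyond the scatter is expected. The expected change is a 1.3-fold lower number from compound 2 to compound 3 (0.13 log units; within the scatter). Compound 3 is estimated at 120 nM, with an expected range of 35 nM to 400 nM.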

Compound 3, half-maximal inhibitory concentration: 5550 nM
For compound 3 the middle estimate is 46-fold (1.67 log units) below the measured one; the measured number lies above the stated range.
By their numbers in this assay, from the lowest: compound 1; then compound 2; then compound 3.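

Swapping (3-(pyrrolidin-1-yl)propyl)carbamoyl for ((pyridin-2-yl)methyl)carbamoyl gives a 34-fold higher number from compound 2 to compound 3 (1.54 log units; beyond the scatter), a large step, so this position responds far more strongly than the earlier pair suggested. The comparison with the dimethylamino chain is larger still, at a 110-fold higher number from compound 1 to compound 3 (2.05 log units; beyond the scatter), and among these three compounds the two with a saturated amine on the chain both give lower numbers than compound 3. Nothing measured here accounts for this difference. As far as these compounds go, it remains open whether the pyridin-2-yl ring or the shorter link matters more, which a 3-(pyridin-2-yl)propyl chain on the same amide could help separate.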